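Thioether-linked coumarins: from nitrile to trifluoromethoxy

This account rests on a few compounds, and the source may have more. Where it says the series, first, only, none or still open, it means among the compounds named here.

Measured compounds:
compound 1, `Cc1cc(=O)oc2cc(SCc3ccccn3)ccc12`, > 35200 nM in a functional assay on A549 cells (Homo sapiens) for antiproliferative activity, read by sulforhodamine B assay, with a stated time of 72 h; a lower number here means a stronger inhibitor of growth, a higher number a weaker inhibitor of growth
compound 2, `Cc1cc(=O)oc2cc(SCc3cccc(C#N)c3)ccc12`, > 32500 nM

Compound 1 has only a limit in this assay, the value > 35200 nM being the upper bound at which growth inhibition was no longer seen. Compound 2 likewise has only a limit, its value > 32500 nM being such a bound, as the line the limit of > 32500 nM in this assay, at which 1 of the 2 values shown sits, records. For the measured compounds named here, neither value is a number, so no step between the two measured compounds can be sized; both sit at a limit.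

Compound 3, `Cc1cc(=O)oc2cc(SCc3cccc(OC(F)(F)F)c3)ccc12`, is not yet measured. It differs from compound 2 by trifluoromethoxy in place of cyano on an aromatic carbon. Going by the values given here, no measured step shows what such a change does in this assay, and with compound 2 at a limit the expected step is best taken as none beyond the scatter; it is expected as a step that the limit leaves unreadable from compound 2 to compound 3. For compound 3 the estimate in this assay is 40000 nM, with a range from 12000 nM to 120000 nM, and most likely the assay again reports only a limit.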

Compound 3, concentration for 50% growth inhibition: 17400 nM
Compound 3: middle estimate off by 2.3-fold (0.36 log units), on the high side, within the range that was stated.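

In this assay compound 3 is the only one of the three compounds shown that gives a number and not a limit, so trifluoromethoxy on this aromatic carbon, meta to a large group, yields growth inhibition that the assay can put a value on. Trifluoromethoxy in place of cyano gives an at least 1.8-fold lower number from compound 2 to compound 3 (0.27 log units; that floor lies within the scatter), which means that the true step may be larger, but the data shown do not establish a change beyond the scatter. The step can be stated only as a floor because compound 2 has a limit and not a number: the limit of > 32500 nM in this assay, at which 1 of the 3 values shown sits.

How large the step really is remains open, since nothing shown places compound 2 on a measured scale. Also open, going by these compounds, is whether a methoxy group, a trifluoromethyl group or an amine on the same aromatic carbon would likewise give a number in this assay, or whether trifluoromethoxy would do so on another carbon of that ring.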